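Series notes: bromo in place of methoxy

The compounds below may be only part of what the source reports. "The series", "measured", "known", "first", "only" and "open" are said of these compounds alone.

Measured in a functional assay on NCI-H1299 cells (Homo sapiens), read by flow cytometry (a higher number here means that more compound is needed for the effect, a lower number that less compound is needed), each value a limit of the assay:
- compound 1 `N#Cc1ncc2nc1OC/C=C\COc1ccc(Cl)cc1NC(=O)N2`: > 10000 nM
- compound 2 `N#Cc1ncc2nc1OCC/C=C\COc1ccccc1NC(=O)N2`: > 10000 nM
- compound 3 `COc1ccc2c(c1)NC(=O)Nc1cnc(C#N)c(n1)OCCCCCO2`: > 10000 nM

In this assay, compound 3 gives > 10000 nM, which is a limit and not a number. The series offers no numeric reading so far, only (the limit of > 10000 nM in this assay, at which 3 of the 3 values shown sit). Compound 4 `N#Cc1ncc2nc1OCCCCCOc1ccc(Br)cc1NC(=O)N2` carries bromo in place of methoxy on an aromatic carbon. For the measured compounds named here, no measured step is available to size this change. The expected step is an at least 1.4-fold lower number from compound 3 to compound 4 (0.15 log units; that floor lies within the scatter), small and toward a lower number, and another reading at the limit remains likely. For compound 4 the estimate is 7000 nM, with an expected range of 2000 nM to 10000 nM.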

Compound 4, half-maximal effective concentration: 10000 nM
Compound 4: middle estimate off by 1.4-fold (0.15 log units), on the low side, and the stated range covers the measured number.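

In this assay, bromo in place of methoxy on this aromatic carbon gives a number no higher from compound 3 to compound 4 (the limit leaves the size open), so the size of the step cannot be read. For the compounds shown here, compound 4 gives 10000 nM, the first number rather than a limit, but it stands at the very edge of the readable range. Most of the series remains at one reading: the limit of > 10000 nM in this assay, at which 3 of the 4 values shown sit.

Still open, from the compounds shown here alone, is whether an amine or a carboxylic acid on this aromatic carbon would give a number clear of that limit. Also open, going by these compounds, is how a longer chain in the large ring would read with bromo in place.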